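This account rests on a few compounds, and the source may have more. Where it says the series, first, only, none or still open, it means among the compounds named here.

In a functional assay on HT-29 cells (Homo sapiens) for antiproliferative activity, read by sulforhodamine B assay, with a stated time of 48 h (a lower number here means a stronger inhibitor, a higher number a weaker inhibitor), compound 1 (`COc1ccccc1OS(=O)(=O)c1ccc(N2CCN(C)C2=O)cc1`) gives 26000 nM, the highest of the three numbers in hand, which makes it the weakest inhibitor of the set. Two chlorine-bearing analogues sit lower: compound 2 (`CN1CCN(c2ccc(S(=O)(=O)Oc3cc(Cl)c(Cl)cc3Cl)cc2)C1=O`) gives 600 nM and compound 3 (`CN1CCN(c2ccc(S(=O)(=O)Oc3c(Cl)cc(Cl)cc3Cl)cc2)C1=O`) gives 2500 nM. Compound 4 (`COc1cccc(OS(=O)(=O)c2ccc(N3CCN(C)C3=O)cc2)c1`) has yet to be measured. It has the same atoms as compound 1, joined differently, with 3-methoxyphenyl in place of 2-methoxyphenyl on an oxygen. Among the measured compounds shown here, no measured pair isolates this change, so the expectation stays close to compound 1 at 26000 nM, with no shift beyond the scatter in this assay. The expected change is a 1.4-fold lower number from compound 1 to compound 4 (0.16 log units; within the scatter). The estimate for compound 4 is 18000 nM, with an expected range of 5000 nM to 50000 nM.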

Compound 4, half-maximal inhibitory concentration: 2500 nM
The estimate for compound 4 lay 7.2-fold (0.86 log units) above the measured number; the measured number lies below the stated range.
By their numbers in this assay, from the lowest: compound 2; then compounds 3 and 4 (each within the scatter of the next); then compound 1.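

In this assay, 3-methoxyphenyl in place of 2-methoxyphenyl on the oxygen bonded to the sulfonyl sulfur gives a 10-fold lower number from compound 1 to compound 4 (1.02 log units; beyond the scatter). Among the compounds shown here, the atoms stay the same, so this large step comes from how the methoxyphenyl group is joined alone, something no earlier pair of compounds could isolate. Nothing available explains the step.

The compounds shown leave open whether an ethoxy or a hydroxy group in place of the methoxy would keep this step. They also leave open whether it would hold on a different core.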